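A few compounds are considered here, and "the series" means these few. Any claim that something is new, unique, unknown or untested is made for them only; others in the source may bear on it.

Compound 1 `Nc1nc(-c2ccccc2)nc2sc(-c3ccccc3)nc12` gives 84 nM in an assay on CHO cells for displacement of a labelled ligand from adenosine receptor A3 (Homo sapiens), read by scintillation counting, with a stated time of 3 h; a higher number here means a weaker inhibitor, a lower number a stronger inhibitor. Going by the values given here, compound 2 `Nc1nc(-c2cccc(CO)c2)nc2sc(-c3ccccc3)nc12` gives 3.7 nM in this assay, and the single measured step, a 23-fold lower number from compound 1 to compound 2 (1.36 log units; beyond the scatter), separates the two. Among the compounds with values here, compound 2 therefore stands at the lowest of the two numbers, and compound 1 is its only neighbour, set apart by that large step. Compound 3 `Nc1nc(-c2ccc(CO)cc2)nc2sc(-c3ccccc3)nc12` differs from compound 2 by 4-(hydroxymethyl)phenyl in place of 3-(hydroxymethyl)phenyl on an aromatic carbon, so the hydroxymethyl is kept but carried on a different ring carbon. Within the data shown here, the one step on record, a 23-fold lower number from compound 1 to compound 2 (1.36 log units; beyond the scatter), bears on it only indirectly: it shows that the hydroxymethyl itself brings a large gain, but nothing measured tells whether the 4-(hydroxymethyl)phenyl arrangement holds that gain. Compound 3 is therefore expected to show a moderate rise, a 4.1-fold higher number from compound 2 to compound 3 (0.61 log units; beyond the scatter), in this assay. Compound 3 is estimated at 15 nM, with a range from 2.5 nM to 120 nM.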

Compound 3, inhibition constant: 8.2 nM
For compound 3 the middle estimate is 1.8-fold (0.26 log units) above the measured one, within the range that was stated.
By their numbers in this assay, from the lowest: compound 2; then compound 3; then compound 1.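

Moving the hydroxymethyl to another ring carbon changes little in this assay: 4-(hydroxymethyl)phenyl in place of 3-(hydroxymethyl)phenyl gives only a modest loss (a 2.2-fold higher number from compound 2 to compound 3 (0.35 log units; beyond the scatter)). The gain over the plain phenyl of compound 1 therefore does not depend on a single ring carbon, and it remains large at the new place (a 10-fold lower number from compound 1 to compound 3 (1.01 log units; beyond the scatter)), although compound 2 keeps the lower number. No independent evidence on hand accounts for the difference between the two placements.

The compounds shown leave open whether the hydroxyl itself carries the gain, which a methoxymethyl, an aminomethyl or a carboxylic acid on the same ring could test. They also leave open whether a longer chain, such as hydroxyethyl, would keep the gain at either ring carbon.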